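Shortening the Amide Chain from Compound 3 to Compound 4

The source may hold more compounds than are shown below. What is called first, only, known or untested is meant among the compounds shown, and "the series" means these compounds.

Compound 1 `Cc1c(C(=O)O)sc2ncnc(Nc3ccc(F)cc3)c12`, the carboxylic acid, gives 164 nM in an assay on isolated protein for inhibition of MAP kinase-interacting serine/threonine-protein kinase 2 (Homo sapiens), read by TR-FRET, with stated times of 10 min and 90 min; on this read-out lower numbers stand for stronger inhibition and higher numbers for weaker inhibition. Compound 2 `Cc1c(C(N)=O)sc2ncnc(Nc3ccc(F)cc3OC(C)C)c12`, the unsubstituted amide, gives 110 nM in this assay. Compound 3 `COCCCNC(=O)c1sc2ncnc(Nc3ccc(F)cc3OC(C)C)c2c1C` carries a 3-methoxypropyl group on the amide nitrogen and gives 164 nM in this assay. Among the three measured compounds, compound 3 stands level with compound 1 at the digits shown, and together they hold the highest numbers, while the step of a 1.5-fold higher number from compound 2 to compound 3 (0.17 log units; within the scatter) shows what attaching the chain to the amide nitrogen did.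

Compound 4 `CNC(=O)c1sc2ncnc(Nc3ccc(F)cc3OC(C)C)c2c1C` differs from compound 3 in one place: hydrogen in place of 2-methoxyethyl on a saturated chain carbon bound to an amide-type nitrogen. Of the measured steps, only a 1.5-fold higher number from compound 2 to compound 3 (0.17 log units; within the scatter) bears on this change, since it concerns the same amide nitrogen, and that step stayed within the scatter. Compound 4 keeps a methyl on the amide nitrogen, a smaller substituent than in compound 3 but not the bare hydrogen of compound 2, so the expected step of a 1.3-fold lower number from compound 3 to compound 4 (0.10 log units; within the scatter) is small, leaning if anything toward a lower number, and not beyond the scatter. For compound 4 the estimated value in this assay is 130 nM, with a range from 60 nM to 300 nM.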

Compound 4, inhibition constant: 18 nM
Compound 4: the middle estimate sits 7.2-fold (0.86 log units) above what was measured; the measured number lies below the stated range.
By their numbers in this assay, from the lowest: compound 4; then compounds 2, 1 and 3 (each within the scatter of the next).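

Going by these compounds alone, the amide nitrogen proves far more sensitive to its substituent than the earlier compounds suggested: in this assay, exchanging 3-methoxypropyl for methyl gives a 9.1-fold lower number from compound 3 to compound 4 (0.96 log units; beyond the scatter), whereas adding the chain to the bare amide had given only a 1.5-fold higher number from compound 2 to compound 3 (0.17 log units; within the scatter). The methyl group also stands apart from hydrogen, with a 6.1-fold lower number from compound 2 to compound 4 (0.79 log units; beyond the scatter), so among these three amides the numbers do not follow chain length: hydrogen and 3-methoxypropyl remain within the scatter of each other, while methyl gives the lowest number of the three. No measured evidence is available here to account for this difference.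

The compounds shown leave open whether the low number belongs to methyl alone or would persist with an ethyl or a cyclopropyl group on the amide nitrogen, and whether a second methyl on that nitrogen would keep it. They also leave open whether the ether oxygen of the longer chain plays any part in the higher number of compound 3, a question that a plain butyl chain could address.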